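From compound 2 to compound 4: one group exchanged

A few compounds are considered here, and "the series" means these few. Any claim that something is new, unique, unknown or untested is made for them only; others in the source may bear on it.

In a functional assay on V79 cells (Cricetulus griseus) for cytotoxicity, read by colony formation (on this read-out lower numbers stand for stronger inhibition and higher numbers for weaker inhibition), compound 1 `CC1(CN)CCN(c2c(F)cc3c(=O)c(C(=O)O)cn(C4CC4)c3c2F)C1` gives 8 ug/mL and compound 2 `CC1(CN)CCN(c2c(F)cc3c(=O)c(C(=O)O)cn(C4CC4)c3c2Cl)C1` gives 8 ug/mL which means no change at the digits printed from compound 1 to compound 2 (within the scatter) for chloro in place of fluoro. Compound 3 `COc1c(N2CCC(C)(CN)C2)c(F)cc2c(=O)c(C(=O)O)cn(C3CC3)c12` gives 38 ug/mL and methoxy brings a 4.8-fold higher number from compound 1 to compound 3 (0.68 log units; beyond the scatter) and a 4.8-fold higher number from compound 2 to compound 3 (0.68 log units; beyond the scatter) as its two steps. Compound 2 thus shares the lowest number of the three with compound 1. Compound 4 `NC1CCN(c2c(F)cc3c(=O)c(C(=O)O)cn(C4CC4)c3c2Cl)CC1` carries 4-aminopiperidin-1-yl in place of 3-(aminomethyl)-3-methylpyrrolidin-1-yl on an aromatic carbon and keeps everything else. For the measured compounds named here, no measured step changes this group, so none of them speaks directly to the exchange. No step beyond the scatter is therefore expected in this assay and the estimated step is a 1.3-fold higher number from compound 2 to compound 4 (0.10 log units; within the scatter) with wide uncertainty. Compound 4 is estimated at 10 ug/mL with an expected range from 3 ug/mL to 35 ug/mL on this read-out.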

Compound 4, half-maximal inhibitory concentration: 18 ug/mL
The estimate for compound 4 lay 1.8-fold (0.26 log units) below the measured number; measured number inside the range.
By their numbers in this assay, from the lowest: compounds 1 and 2 (each within the scatter of the next); then compound 4; then compound 3.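

In this assay, 4-aminopiperidin-1-yl in place of 3-(aminomethyl)-3-methylpyrrolidin-1-yl brings a 2.3-fold higher number from compound 2 to compound 4 (0.35 log units; beyond the scatter). For the compounds shown here, the earlier compounds all carried the same group at this aromatic carbon, so this is the first sign that the read-out also responds to a change here, and not only to the group ortho to it. No measurement at hand bears on why the number rises.

As far as these compounds go, it remains open whether the same exchange has a similar effect with fluoro or methoxy in place of chloro. Also open, from the compounds shown here alone, is how a piperazine or a 3-aminopyrrolidin-1-yl group would read at this position.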